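Swapping tert-butyl for methanesulfonamido on the aryl ring

The source may hold more compounds than are shown below. What is called first, only, known or untested is meant among the compounds shown, and "the series" means these compounds.

Compound 1 `CCCCc1ccccc1N1CCN(CCCCCC(=O)NC2CCCc3ccccc32)CC1`: 2810 nM
Compound 2 `CC(C)(C)c1ccccc1N1CCN(CCCCCC(=O)NC2CCCc3ccccc32)CC1`: 538 nM
Compound 3 `CNc1ccccc1N1CCN(CCCCCC(=O)NC2CCCc3ccccc32)CC1`: 25.4 nM

In an assay on HEK293 cells for displacement of a labelled ligand from 5-hydroxytryptamine receptor 7 (Rattus norvegicus) (a lower number here means a stronger inhibitor, a higher number a weaker inhibitor), compound 2 holds the second highest of the three numbers, standing between compound 1 and compound 3. Compound 4 `CS(=O)(=O)Nc1ccccc1N1CCN(CCCCCC(=O)NC2CCCc3ccccc32)CC1` differs from compound 2 by methanesulfonamido in place of tert-butyl on an aromatic carbon. For the measured compounds named here, two measured steps bear on this change. Exchanging one carbon-only group for another gave a 5.2-fold lower number from compound 1 to compound 2 (0.72 log units; beyond the scatter), a modest shift. Putting a nitrogen-bearing group in place of the tert-butyl gave a 21-fold lower number from compound 2 to compound 3 (1.33 log units; beyond the scatter), and the run from compound 1 to compound 3 was a 110-fold lower number from compound 1 to compound 3 (2.04 log units; beyond the scatter). Since the entering group, like methylamino, brings a hydrogen-bond donor, a step of a 4.5-fold lower number from compound 2 to compound 4 (0.65 log units; beyond the scatter) is expected in this assay. Compound 4 is therefore estimated at 120 nM, within a range from 25 nM to 600 nM.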

Compound 4, inhibition constant: 4250 nM
Estimate against measurement, compound 4: 35-fold (1.55 log units) below; the whole stated range lies below it.
By their numbers in this assay, from the lowest: compound 3; then compound 2; then compounds 1 and 4 (each within the scatter of the next).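

In this assay a hydrogen-bond donor on this aromatic carbon does not by itself bring the gain seen with methylamino: methanesulfonamido also carries one, yet replacing tert-butyl gives a 7.9-fold higher number from compound 2 to compound 4 (0.90 log units; beyond the scatter) overall, and methylsulfonyl in place of methyl on the nitrogen gives a 170-fold higher number from compound 3 to compound 4 (2.22 log units; beyond the scatter) at this place. Butyl and methanesulfonamido give values that cannot be told apart, with a 1.5-fold higher number from compound 1 to compound 4 (0.18 log units; within the scatter) between them. Nothing measured here gives a reason for this result.

From the compounds shown here alone, whether an unsubstituted amine or an acetamido group at this place would stay near compound 3 or fall toward compound 4 remains open.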